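Demethylation of the aryl ether in the pyrazole series

The source may report more compounds than this note shows. Statements on the series, on what has been measured and on what is new or still open speak of the compounds shown alone.

Measured compounds:
- compound 1, `COc1cc(C)cc(-c2nn(CC#N)cc2-c2ccc(-c3cccc(C(C)=O)c3)nc2)c1`: 81400 nM
- compound 2, `Cc1cc(O)cc(-c2nn(CC#N)cc2-c2ccnc(-c3ccc(Oc4ccccc4)cc3)c2)c1`: 15500 nM
- compound 3, `COc1cc(C)cc(-c2nn(CC#N)cc2-c2ccnc(-c3ccc(N(C)C)cc3)c2)c1`: 8900 nM

In a functional assay on SF-268 cells (Homo sapiens) for inhibition, read by sulforhodamine B assay, with a stated time of 48 h (a lower number here means a stronger inhibitor of growth, a higher number a weaker inhibitor of growth), compound 3 gives 8900 nM, the lowest of the three numbers. Compound 2 gives 15500 nM, which lies within the scatter of compound 3, so the two cannot be separated on these data. Compound 1 gives 81400 nM, a gap to compound 3 that is beyond the scatter; compound 1 also differs from compound 3 in more than one place, so nothing is attributed to a single change here.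

Compound 4, `Cc1cc(O)cc(-c2nn(CC#N)cc2-c2ccnc(-c3ccc(N(C)C)cc3)c2)c1`, has not yet been measured. It differs from compound 3 by hydrogen in place of methyl on an oxygen on an aromatic ring, that is methoxy to hydroxy, 3-methoxy-5-methylphenyl to 3-hydroxy-5-methylphenyl. Among the compounds with values here, no measured pair isolates this change, and compound 2, the only other hydroxy compound, differs from compound 3 in a second place as well. On these data the step from compound 3 to compound 4 is expected to be small, with no direction that can be called beyond the scatter, giving a 1.0-fold lower number from compound 3 to compound 4 (0.02 log units; within the scatter). Compound 4 is therefore estimated at 8500 nM in this assay, with a range of 3000 nM to 25000 nM.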

Compound 4, concentration for total growth inhibition: 16900 nM
Beside the measured number, compound 4's estimate is 2.0-fold (0.30 log units) below it, within the range that was stated.
By their numbers in this assay, from the lowest: compounds 3, 2 and 4 (each within the scatter of the next); then compound 1.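

Notes on the methoxy to hydroxy change: in this assay, hydrogen in place of methyl on an oxygen on an aromatic ring can now be read on its own, and it gives a 1.9-fold higher number from compound 3 to compound 4 (0.28 log units; within the scatter) with the dimethylamino group held constant, so on this pair the 3-methoxy-5-methylphenyl and 3-hydroxy-5-methylphenyl forms cannot be separated. With the 3-hydroxy-5-methylphenyl group held constant, dimethylamino in place of phenoxy on an aromatic carbon gives a 1.1-fold higher number from compound 2 to compound 4 (0.04 log units; within the scatter) and likewise cannot be separated, so neither single change shown here moves the number beyond the scatter. No measured property or other outside data bear on either step, and the notes offer no explanation for them.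

As far as these compounds go, each change rests on a single pair, so it remains open whether methoxy to hydroxy reads the same on a different substitution pattern, such as the core of compound 1. From the compounds shown here alone, it also remains open whether a longer chain on this oxygen, such as an ethyl or propyl ether, or an amine in place of the oxygen would give a step beyond the scatter.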